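The compounds below may be only part of what the source reports. "The series", "measured", "known", "first", "only" and "open" are said of these compounds alone.

Measured in a functional assay on PC-3 cells (Homo sapiens) for cytotoxicity, read by MTT assay, with a stated time of 72 h; a higher number here means a weaker inhibitor, a lower number a stronger inhibitor:

- Compound 1 `COc1ccc(OC)c(C(=O)/C=C/c2ccc(C(=O)OC(C)C)cc2)c1`: 6740 nM
- Compound 2 `COc1ccc(OC)c(C(=O)/C=C/c2ccc(C(=O)OCC=C(C)C)cc2)c1`: > 50000 nM (a limit of the assay)
- Compound 3 `CCNC(=O)c1ccc(/C=C/C(=O)c2cc(OC)ccc2OC)cc1`: 4180 nM

Compound 3 stands level with compound 1 within the scatter, as ethylamino in place of isopropoxy on the carbonyl carbon gives a 1.6-fold lower number from compound 1 to compound 3 (0.21 log units; within the scatter). The value of compound 2 is a limit, and reaching compound 3 from it gives an at least 11-fold lower number from compound 2 to compound 3 (1.07 log units; beyond the scatter).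

The next compound is compound 4 `COc1ccc(OC)c(C(=O)/C=C/c2ccc(C(=O)NC3CCCCC3)cc2)c1`, which carries cyclohexyl in place of ethyl on an amide-type nitrogen. For the measured compounds named here, no measured step changes this nitrogen substituent, so the evidence is indirect. The closest guide is the exchange of isopropyl for 3-methylbut-2-en-1-yl in compound 2, an at least 7.4-fold higher number from compound 1 to compound 2 (0.87 log units; beyond the scatter), which warns of a possible rise in the number. Compound 3 offers no such warning, so only a small upward move is expected in this assay. The estimated step is a 1.7-fold higher number from compound 3 to compound 4 (0.22 log units; within the scatter). For compound 4 the expected value is 7000 nM, with an estimated range from 2500 nM to 25000 nM.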

Compound 4, half-maximal inhibitory concentration: 6300 nM
Estimate against measurement, compound 4: 1.1-fold (0.05 log units) above; the measured number falls inside the stated range.
By their numbers in this assay, from the lowest: compounds 3, 4 and 1 (each within the scatter of the next). At a limit, above all of these: compound 2.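

In this assay, the amide-type nitrogen carries cyclohexyl as well as ethyl with no difference beyond the scatter (a 1.5-fold higher number from compound 3 to compound 4 (0.18 log units; within the scatter)), so this position accepts a six-membered carbon ring at the size of the step shown here. Cyclohexylamino on the carbonyl carbon also stands level with isopropoxy (a 1.1-fold lower number from compound 1 to compound 4 (0.03 log units; within the scatter)), which places the two amides and the isopropyl ester together. Only the (3-methylbut-2-en-1-yl)oxy group stands apart, with cyclohexylamino in its place giving an at least 7.9-fold lower number from compound 2 to compound 4 (0.89 log units; beyond the scatter) as a step that rests on a limit of the assay: the limit of > 50000 nM in this assay, at which 1 of the 4 values shown sits.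

The compounds shown leave open whether a phenyl ring or a longer chain on this nitrogen would stay level too. They also leave open what a hydroxyl group or an amine on the cyclohexyl ring would do.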